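A Halogenated Ring Replaces a Methylphenyl Group

The source may report more compounds than this note shows. Statements on the series, on what has been measured and on what is new or still open speak of the compounds shown alone.

Compound 3 `Cc1ccc(-n2nc(C(=O)Nc3ccc(Oc4ncnc5[nH]ccc45)cc3)c(C)cc2=O)cc1` gives 6400 nM in a functional assay on A549 cells (Homo sapiens) for cytotoxicity, read by MTT assay, with a stated time of 72 h (a lower number here means a stronger inhibitor, a higher number a weaker inhibitor), the lowest of the two numbers shown. Compound 1 `Cn1ccc2c(Oc3ccc(NC(=O)c4nn(-c5ccc(Br)cc5F)ccc4=O)cc3F)ccnc21` gives 26800 nM in this assay. For compound 2 `Cn1ccc2c(Oc3ccc(NC(=O)c4nn(-c5ccc(Cl)c(F)c5)ccc4=O)cc3F)ccnc21` this assay reports only a limit, > 60000 nM. Compound 4 `Cc1cc(=O)n(-c2ccc(Br)cc2F)nc1C(=O)Nc1ccc(Oc2ncnc3[nH]ccc23)cc1` is not yet measured; it differs from compound 3 by 4-bromo-2-fluorophenyl in place of 4-methylphenyl on an aromatic nitrogen. For the measured compounds named here, the only measured step at this position, an at least 2.2-fold higher number from compound 1 to compound 2 (0.35 log units; beyond the scatter), exchanges one halogenated ring for another and does not test a methyl against a halogen; it shows only that the group on this nitrogen can shift the result beyond the scatter, with the 4-bromo-2-fluorophenyl giving the lower number. Going by the values given here, no measured step shows the same exchange, so the expected step is small, a 1.3-fold higher number from compound 3 to compound 4 (0.10 log units; within the scatter), within the scatter. Compound 4 is estimated at 8000 nM, with a range from 3000 nM to 25000 nM.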

Compound 4, half-maximal inhibitory concentration: 3770 nM
The estimate for compound 4 lay 2.1-fold (0.33 log units) above the measured number; the measured number falls inside the stated range.
By their numbers in this assay, from the lowest: compounds 4 and 3 (each within the scatter of the next); then compound 1. At a limit, above all of these: compound 2.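

In this assay, placing 4-bromo-2-fluorophenyl on the aromatic nitrogen in place of 4-methylphenyl gives a 1.7-fold lower number from compound 3 to compound 4 (0.23 log units; within the scatter), so the two rings cannot be told apart on this core. For the compounds shown here, this is the first measured step at this position that compares a halogenated ring with a methyl-bearing one, whereas the earlier step compared only two halogenated rings. No measurement shown explains this result. The compounds shown leave open whether a phenyl ring carrying an amine or a carboxylic acid on this nitrogen would move the number beyond the scatter.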